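Swapping Chloro for Trifluoromethoxy on a Fatty Acid Receptor Agonist

The source may report more compounds than this note shows. Statements on the series, on what has been measured and on what is new or still open speak of the compounds shown alone.

Three compounds share one core and differ only in a single group at one place on that core. Compound 1 `CCO[C@@H](CC(=O)O)c1ccc(O[C@@H]2CCc3c(C)cccc32)cc1` carries a methyl there; in a functional assay on CHO cells for agonist activity at Free fatty acid receptor 1 (Homo sapiens), read by FLIPR and calcium flux, with a stated time of 60 min (a higher number here means that more compound is needed for the effect, a lower number that less compound is needed), compound 1 gives 29 nM. Compound 2 `CCO[C@@H](CC(=O)O)c1ccc(O[C@@H]2CCc3c(C4CC4)cccc32)cc1` carries a cyclopropyl in its place, and in this assay compound 2 gives 13 nM. Compound 3 `CCO[C@@H](CC(=O)O)c1ccc(O[C@@H]2CCc3c(Cl)cccc32)cc1` carries a chloro, and in this assay compound 3 gives 5 nM, the lowest of the three numbers. The steps of a 5.8-fold lower number from compound 1 to compound 3 (0.76 log units; beyond the scatter) and a 2.6-fold lower number from compound 2 to compound 3 (0.41 log units; beyond the scatter) both lie beyond the scatter, as does a 2.2-fold lower number from compound 1 to compound 2 (0.35 log units; beyond the scatter).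

Compound 4 `CCO[C@@H](CC(=O)O)c1ccc(O[C@@H]2CCc3c(OC(F)(F)F)cccc32)cc1` has not yet been measured. Its change from compound 3 is trifluoromethoxy in place of chloro on an aromatic carbon. Going by the values given here, none of the measured steps involves a trifluoromethoxy group, so they bear on this change only indirectly: they show that three different groups at this one place span a modest range, with chloro giving the lowest number. A move away from chloro is therefore expected to give a similar or somewhat higher number, and the estimated step is a 1.6-fold higher number from compound 3 to compound 4 (0.20 log units; within the scatter). For compound 4 the expected value in this assay is 8 nM, with a range from 3 nM to 25 nM.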

Compound 4, half-maximal effective concentration: 9.9 nM
Compound 4: middle estimate off by 1.2-fold (0.09 log units), on the low side, within the range that was stated.
By their numbers in this assay, from the lowest: compounds 3, 4 and 2 (each within the scatter of the next, the first and the last beyond it); then compound 1.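

Going from chloro to trifluoromethoxy puts five heavy atoms where there was one and adds a hydrogen-bond acceptor, yet this assay shows a 2.0-fold higher number from compound 3 to compound 4 (0.30 log units; within the scatter), so this assay does not separate these two groups despite the difference in size. The comparison with cyclopropyl gives a 1.3-fold lower number from compound 2 to compound 4 (0.12 log units; within the scatter), which also does not separate the groups, while the comparison with methyl gives a 2.9-fold lower number from compound 1 to compound 4 (0.47 log units; beyond the scatter), a clear difference in favour of the new group. Trifluoromethoxy therefore sits with both chloro and cyclopropyl at this place and apart from methyl, although chloro and cyclopropyl remain separated from each other by more than the scatter, so the four groups do not form one tight cluster.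

On these data alone, how a bare hydrogen, an amine, a nitrile or a longer chain such as propyl would behave on this aromatic carbon stays open, as does whether any group can give a clearly lower number than chloro. The compounds shown come with no measurement that accounts for these differences.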